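Piperazin-1-yl for piperidin-1-yl on the propyl chain

This account rests on a few compounds, and the source may have more. Where it says the series, first, only, none or still open, it means among the compounds named here.

Compound 1 `CC(C)N1CCC(COc2ccc(-c3nc4ccc(Oc5ccc(Cl)cc5)cc4o3)cc2)CC1`: 26.2%
Compound 2 `N[C@H]1CCN(CCCOc2ccc(-c3nc4ccc(Oc5ccc(Cl)cc5)cc4o3)cc2)C1`: 29.9%
Compound 3 `Clc1ccc(Oc2ccc3nc(-c4ccc(OCCCN5CCCCC5)cc4)oc3c2)cc1`: 2.2%

In an assay on isolated protein for inhibition of advanced glycosylation end product-specific receptor (Homo sapiens), read by FRET, with stated times of 30 min and 1 h, tested at 4 uM (a lower number here means less inhibition, a higher number more inhibition at the concentration tested (going by the name of the read-out)), compound 3 gives the lowest of the three numbers; the steps of a number 24 percentage points lower from compound 1 to compound 3 (beyond the scatter) and a number 27.7 percentage points lower from compound 2 to compound 3 (beyond the scatter) both lie beyond the scatter, while a number 3.7 percentage points higher from compound 1 to compound 2 (within the scatter) does not. Compound 4 `Clc1ccc(Oc2ccc3nc(-c4ccc(OCCCN5CCNCC5)cc4)oc3c2)cc1` differs from compound 3 by piperazin-1-yl in place of piperidin-1-yl on a saturated chain carbon, three bonds along the chain from an oxygen on an aromatic ring. For the measured compounds named here, no measured pair shows exactly this change. The nearest is the step from compound 2 to compound 3, where a ring without a hydrogen-bond donor replaced one with a donor and the number fell; compound 4 restores a donor in the ring. A modest rise is therefore expected for compound 4, giving a number 12.8 percentage points higher from compound 3 to compound 4 (beyond the scatter), with an estimated value of 15% in the range 0% to 35%.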

Compound 4, a percentage reported as inhibition, at one concentration (the size of the read-out at that concentration, not a potency): 42.7%
Estimate against measurement, compound 4: 27.7 percentage points below; the whole stated range lies below it.
By their numbers in this assay, from the lowest: compound 3; then compounds 1 and 2 (each within the scatter of the next); then compound 4.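

In this assay, for the compounds shown here, the change from piperidin-1-yl to piperazin-1-yl on the propyl chain gives a number 40.5 percentage points higher from compound 3 to compound 4 (beyond the scatter) and is the largest step at this position so far. The piperazin-1-yl end also exceeds the other two amine ends, with a number 12.8 percentage points higher from compound 2 to compound 4 (beyond the scatter) and a number 16.5 percentage points higher from compound 1 to compound 4 (beyond the scatter) in this series, so compound 4 now stands highest of the four. Nothing measured here explains why this one ring change counts for so much. Going by these compounds, what a 4-methylpiperazin-1-yl or a morpholin-4-yl group on the same propyl chain would give remains open, as does a longer chain carrying piperazin-1-yl.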